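Enantiomer swap at the chain stereocentre, cytotoxicity read-out

The source may hold more compounds than are shown below. What is called first, only, known or untested is meant among the compounds shown, and "the series" means these compounds.

Compound 2 `Clc1ccc([C@@H](CCn2cncn2)Cc2ccccc2)cc1` is the point of departure. In an ADME assay on RD cells (Homo sapiens) for cytotoxicity, read by MTT assay, with a stated time of 3 days (on this read-out higher numbers stand for lower toxicity in this test and lower numbers for higher toxicity in this test), compound 2 gives 24.4 ug/mL. Among the compounds with values here, the only other value comes from compound 1 `CCC[C@@H](CCn1cncn1)c1ccc(Cl)cc1`, which in this assay gives 40.8 ug/mL; the two numbers lie within the scatter of each other, so no order between them is claimed. Compound 3 `Clc1ccc([C@H](CCn2cncn2)Cc2ccccc2)cc1` has not yet been measured. It differs from compound 2 as follows: the two compounds have the same atoms and bonds and differ only in configuration as drawn: 1 of 1 stereo elements differ; a stereocentre at a saturated chain carbon is drawn R in compound 2 and S in compound 3. Within the data shown here, no pair of measured compounds in this set differs by such a change, so there is no measured step to lean on. For a cytotoxicity read-out of this kind the expectation is no step beyond the scatter in either direction. Compound 3 is therefore expected to give 25 ug/mL in this assay, with a range of 12 ug/mL to 50 ug/mL. The step implied by this estimate is expected to be a 1.0-fold higher number from compound 2 to compound 3 (0.01 log units; within the scatter), flat within the scatter.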

Compound 3, half-maximal cytotoxic concentration: 21.7 ug/mL
Estimate against measurement, compound 3: 1.2-fold (0.06 log units) above, and the stated range covers the measured number.
By their numbers in this assay, from the lowest: compounds 3, 2 and 1 (each within the scatter of the next).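

Inverting the chain stereocentre gives a 1.1-fold lower number from compound 2 to compound 3 (0.05 log units; within the scatter), so configuration at this position does not separate the pair in this assay. Phenyl in place of ethyl on a saturated chain carbon, two bonds along the chain from an aromatic carbon, gives a 1.9-fold lower number from compound 1 to compound 3 (0.27 log units; within the scatter), so this second step also sets no order among the compounds. The first step can be read as a pure test of configuration at this carbon: the fact that compounds 2 and 3 differ only in the configuration as drawn

Still open, going by these compounds, is whether configuration remains equally without effect when that chain carbon carries a longer chain, an amine or a carboxylic acid in place of benzyl. On these data alone, how these cytotoxicity numbers relate to any activity read-out on the series also remains open.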